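Removing the Methoxy Group from a Melatonin Receptor Ligand

The compounds below may be only part of what the source reports. "The series", "measured", "known", "first", "only" and "open" are said of these compounds alone.

Of the compounds shown here, three have so far been tested in an assay on CHO cells for displacement of a labelled ligand from melatonin receptor type 1A (Homo sapiens), with a stated time of 120 min; on this read-out higher numbers stand for weaker inhibition and lower numbers for stronger inhibition. Compound 1 `CCNC(=O)NCC1CCc2c(OC)cccc2N1C` gives 5 nM. Compound 2 `CCC(=O)NCC1CCc2ccc(OC)cc2N1Cc1ccccc1` gives 214 nM, and compound 3 `CCNC(=O)NCC1CCc2ccccc2N1` gives 115 nM. Of these three numbers, compound 2 has the highest, which on this read-out means the weakest inhibition. Its number lies closest to that of compound 3, and that gap falls within the usual scatter of repeated measurements, so the two cannot be ranked against each other. Its gap to compound 1 goes beyond the scatter, so compound 1 is clearly the stronger inhibitor of that pair.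

Compound 4 `CCC(=O)NCC1CCc2ccccc2N1Cc1ccccc1` has not yet been measured. It differs from compound 2 in a single place: hydrogen in place of methoxy on an aromatic carbon. Among the measured compounds shown here, no two measured compounds differ only in this way, so the size of this step cannot be read from a matching example. Compound 3 also lacks a methoxy group, but it differs from compound 2 in other places as well, so the number that compound 3 gives, 115 nM, is not a direct guide.

The expected step is a 7.0-fold higher number from compound 2 to compound 4 (0.85 log units; beyond the scatter), in the direction of weaker inhibition and beyond the scatter. Compound 4 is estimated at 1500 nM, with a range from 300 nM to 8000 nM.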

Compound 4, inhibition constant: 37 nM
For compound 4 the middle estimate is 41-fold (1.61 log units) above the measured one; the whole stated range lies above it.
By their numbers in this assay, from the lowest: compound 1; then compound 4; then compounds 3 and 2 (each within the scatter of the next).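

At this aromatic carbon, hydrogen in place of methoxy gives a 5.8-fold lower number from compound 2 to compound 4 (0.76 log units; beyond the scatter) in this assay, which is a move towards stronger inhibition. Among the compounds shown here, this is the first direct reading of this change, and it shows that in this pair the methoxy group is not needed for inhibition, since the compound without it is the stronger inhibitor. Nothing shown here explains why removing the group has this effect.

On these data alone, this single step comes from one pair, so it remains open whether the same change would shift the number in the same direction on a different version of the molecule, such as one carrying the ethyl urea side chain of compound 1 in place of the propanamide chain of compound 4. Only hydrogen and methoxy are shown at this carbon, so it also remains open how groups such as a fluorine atom, a hydroxyl group or a longer ethoxy group would compare there.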